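Swapping the ester ring: ethyl out, bromine and methyl in

This account rests on a few compounds, and the source may have more. Where it says the series, first, only, none or still open, it means among the compounds named here.

Measured so far:
compound 1, `CN(C)CCC(OC(=O)c1ccc(-c2ccccc2)cc1)c1ccc(Cl)cc1`: 53%
compound 2, `CCc1ccccc1C(=O)OC(CCN(C)C)c1ccc(Cl)cc1`: 128%

In an assay on NIH3T3 cells with Urotensin-2 receptor (Homo sapiens) as the target (a higher number here means a larger maximal response, a lower number a smaller maximal response), compound 2 gives the higher of the two numbers, and compound 1 the lower, a gap beyond the usual scatter. Compound 3, `Cc1cc(Br)ccc1C(=O)OC(CCN(C)C)c1ccc(Cl)cc1`, is not yet measured. It differs from compound 2 in one place: 4-bromo-2-methylphenyl in place of 2-ethylphenyl on a carbonyl carbon. Among the compounds with values here, no measured pair shows such a change, so only a rough expectation is possible. The other ring tried at this place, in compound 1, gave 53%. A moderate fall is expected, a number 33 percentage points lower from compound 2 to compound 3 (beyond the scatter). Compound 3 is estimated at 95%, between 50% and 140%.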

Compound 3, largest response reached (reported as efficacy), in percent of the reference or control that the assay uses: 95%
For compound 3 middle estimate and measured number coincide at the digits printed; the range from low to high includes it.
By their numbers in this assay, from the lowest: compound 1; then compound 3; then compound 2.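

In this assay, putting 4-bromo-2-methylphenyl in place of 2-ethylphenyl gives a number 33 percentage points lower from compound 2 to compound 3 (beyond the scatter). Both groups count 8 heavy atoms and neither carries a hydrogen-bond donor or acceptor, so the maximal response at this position can shift substantially even when those counts stay the same. No measurement here explains the shift.

Bromine and methyl enter together as ethyl leaves, so the share of each in the step stays open. So does the response to an amine or a carboxylic acid on this ring.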